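Nitro to methoxy on the piperidin-1-yl compound

The compounds below may be only part of what the source reports. "The series", "measured", "known", "first", "only" and "open" are said of these compounds alone.

Compound 1 `CCCCCc1nnc2nnc(N3CCCC3)nn12` carries a pentyl chain and a pyrrolidin-1-yl group; in a functional assay on HL-60 cells (Homo sapiens) for cytotoxicity, read by MTT assay, with a stated time of 72 h (a lower number here means a stronger inhibitor, a higher number a weaker inhibitor), compound 1 gives 42500 nM. Compound 2 `O=[N+]([O-])c1ccc(-c2nnc3nnc(N4CCCC4)n3n2)cc1` puts a nitrophenyl on the shared core and keeps the pyrrolidin-1-yl. In this assay compound 2 reaches only > 100000 nM, which is a limit of the assay and not a number (the limit of > 100000 nM in this assay, at which 1 of the 3 values shown sits). Compound 3 `O=[N+]([O-])c1ccc(-c2nnc3nnc(N4CCCCC4)n3n2)cc1` has piperidin-1-yl in place of pyrrolidin-1-yl, and in this assay compound 3 gives 610 nM; the step is an at least 160-fold lower number from compound 2 to compound 3 (2.21 log units; beyond the scatter). Compound 3 therefore holds the lowest of the two numbers shown, the other being compound 1, whose value stands well higher.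

Compound 4 `COc1ccc(-c2nnc3nnc(N4CCCCC4)n3n2)cc1` differs from compound 3 by methoxy in place of nitro on an aromatic carbon. No measured step touches the carbon ring: the single step shown, an at least 160-fold lower number from compound 2 to compound 3 (2.21 log units; beyond the scatter), changes the amine ring only and gives no guidance on exchanging nitro for methoxy. Compound 4 is thus expected to land near compound 3, with no direction claimed and a wide spread, the expected step being a 2.5-fold higher number from compound 3 to compound 4 (0.39 log units; beyond the scatter). The estimate for compound 4 is 1500 nM, between 200 nM and 15000 nM.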

Compound 4, half-maximal inhibitory concentration: 12900 nM
Compound 4: middle estimate off by 8.6-fold (0.93 log units), on the low side; the measured number falls inside the stated range.
By their numbers in this assay, from the lowest: compound 3; then compound 4; then compound 1. At a limit, above all of these: compound 2.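

In this assay, the group on the aromatic carbon matters as well as the amine ring: with the piperidin-1-yl kept, the step is a 21-fold higher number from compound 3 to compound 4 (1.33 log units; beyond the scatter). Within the data shown here, the earlier step touched the amine ring alone, so this is the first sign that the position para to a large group on the six-membered carbon ring is sensitive, with nitro giving the lower number of this pair. Nothing measured here accounts for the difference between nitro and methoxy.

From the compounds shown here alone, a single exchange at this position gives no trend, so it stays open where groups such as a nitrile, an amine or a carboxylic acid would fall relative to nitro and methoxy. Going by these compounds, it is also open whether methoxy in place of nitro moves the number the same way on a pyrrolidin-1-yl compound.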